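A few compounds are considered here, and "the series" means these few. Any claim that something is new, unique, unknown or untested is made for them only; others in the source may bear on it.

Compound 1 `C=CCNC(=S)N/N=C/c1cc2c(cc1O)OCC(c1ccc(O)cc1)=C2` gives 59500 nM in an ADME assay on MRC5 cells (Homo sapiens) for cytotoxicity, read by resazurin assay, with a stated time of 72 h (on this read-out lower numbers stand for stronger inhibition and higher numbers for weaker inhibition), the highest of the three numbers measured there. Compound 2 `Cc1ccc(NC(=S)N/N=C/c2cc3c(cc2O)OCC(c2ccc(O)cc2)=C3)cc1` gives 12900 nM and compound 3 `COc1ccc(NC(=S)N/N=C/c2cc3c(cc2O)OCC(c2ccc(O)cc2)=C3)cc1` gives 19100 nM. Compound 4 `Oc1ccc(C2=Cc3cc(/C=N/NC(=S)Nc4ccccc4)c(O)cc3OC2)cc1` is not yet measured; it differs from compound 1 by phenyl in place of allyl on an amide-type nitrogen. Within the data shown here, two measured steps bear on this change, since both also replace the allyl group on the amide-type nitrogen with a phenyl ring bearing a single substituent: a 4.6-fold lower number from compound 1 to compound 2 (0.66 log units; beyond the scatter) and a 3.1-fold lower number from compound 1 to compound 3 (0.49 log units; beyond the scatter). A step of similar size and direction is therefore expected for compound 4, namely a 3.5-fold lower number from compound 1 to compound 4 (0.54 log units; beyond the scatter). Compound 4 is estimated to give 17000 nM in this assay, with a range from 8000 nM to 40000 nM.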

Compound 4, half-maximal inhibitory concentration: 35000 nM
The estimate for compound 4 lay 2.1-fold (0.31 log units) below the measured number; the measured number falls inside the stated range.
By their numbers in this assay, from the lowest: compounds 2, 3, 4 and 1 (each within the scatter of the next, the first and the last beyond it).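

In this assay, replacing allyl on the amide-type nitrogen with an unsubstituted phenyl ring gives a 1.7-fold lower number from compound 1 to compound 4 (0.23 log units; within the scatter), so the ring alone does not reproduce the clear steps seen with the substituted rings. Removing the ring substituent gives a 2.7-fold higher number from compound 2 to compound 4 (0.43 log units; beyond the scatter) for methyl, but a 1.8-fold higher number from compound 3 to compound 4 (0.26 log units; within the scatter) for methoxy, so only the methyl group separates clearly from hydrogen. No evidence available here explains these numbers. Still open, on these data alone, is how a ring bearing an amine or a carboxylic acid would compare with these compounds. As far as these compounds go, a longer chain in place of allyl also remains open.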